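Shortening the chain on the aromatic nitrogen of compound 2

The source may hold more compounds than are shown below. What is called first, only, known or untested is meant among the compounds shown, and "the series" means these compounds.

Compound 1, `Nc1ncnc2c1nc(-c1ccco1)n2CCCO`, in an assay on CHO cells for displacement of a labelled ligand from adenosine receptor A1 (Homo sapiens); a higher number here means a weaker inhibitor, a lower number a stronger inhibitor: 60 nM
Compound 2, `CCCn1c(-c2ccco2)nc2c(N)ncnc21`, in this assay: 19 nM
Compound 3, `Cc1ccc(NC(=O)Nc2ncnc3c2nc(-c2ccco2)n3C)cc1`, in this assay: 756 nM

Among the three numbers in this assay, compound 2 carries the lowest. Compound 1 stands nearest to it, separated by the step of a 3.2-fold lower number from compound 1 to compound 2 (0.50 log units; beyond the scatter), and compound 3 stands furthest, with a gap that is also beyond the scatter.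

Compound 4, `Cn1c(-c2ccco2)nc2c(N)ncnc21`, differs from compound 2 by hydrogen in place of ethyl on a saturated chain carbon bound to an aromatic nitrogen. Among the measured compounds shown here, only one measured step touches the same chain: a 3.2-fold lower number from compound 1 to compound 2 (0.50 log units; beyond the scatter), in which a change at the far end of that chain moved the number modestly, beyond the scatter. For the measured compounds named here, compound 3 also carries methyl rather than propyl on the aromatic nitrogen, but it bears a urea on the amine as well, and no single-change step connects it to compound 2 or compound 4, so its higher number is only a hint.

Taken together, the account expects a modest rise in this assay from compound 2 to compound 4, a step of about a 4.2-fold higher number from compound 2 to compound 4 (0.62 log units; beyond the scatter), likely beyond the scatter. Compound 4 is therefore estimated at 80 nM, within a range from 25 nM to 300 nM.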

Compound 4, inhibition constant: 62 nM
Compound 4: middle estimate off by 1.3-fold (0.11 log units), on the high side, within the range that was stated.
By their numbers in this assay, from the lowest: compound 2; then compounds 1 and 4 (each within the scatter of the next); then compound 3.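

In this assay, the step of a 3.3-fold higher number from compound 2 to compound 4 (0.51 log units; beyond the scatter) shows that cutting propyl to methyl on the aromatic nitrogen costs about as much as placing hydroxy on the saturated chain carbon three bonds along the chain from that nitrogen. The step of a 1.0-fold higher number from compound 1 to compound 4 (0.01 log units; within the scatter) lies within the scatter, so compound 1 and compound 4 cannot be told apart here, even though their chains differ by the 2-hydroxyethyl group: among these three compounds, the advantage of the longer chain appears only in compound 2, and the hydroxy-bearing chain of compound 1 goes against any reading based on chain length alone. Nothing given here accounts for these numbers.

The compounds shown leave open how an ethyl or a butyl chain on the aromatic nitrogen would fall relative to methyl and propyl, and so whether the number follows chain length steadily or propyl stands out. They also leave open whether an amine or a methoxy group at the end of the propyl chain would behave as hydroxy does, and whether the propyl to methyl step would hold on a core bearing a urea on the amine.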